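The source may report more compounds than this note shows. Statements on the series, on what has been measured and on what is new or still open speak of the compounds shown alone.

Measured so far:
compound 1, `CCc1ccc(-n2nc(-c3ccc(C(F)(F)F)cc3O)nc2-c2ccccc2O)cc1`: 107%
compound 2, `Oc1cc(C(F)(F)F)ccc1-c1nc(-c2ccccc2O)n(-c2ccc(OC(F)(F)F)cc2)n1`: 92.5%
compound 3, `Oc1cc(C(F)(F)F)ccc1-c1nc(-c2ccccc2O)n(-c2cccc(Cl)c2)n1`: 100%

In a functional assay on PC-12 cells (Rattus norvegicus) for cytotoxicity, read by MTT assay, with stated times of 2 h and 24 h, tested at 10 uM (on this read-out lower numbers stand for a weaker effect and higher numbers for a stronger effect at the one concentration tested), compound 3 gives 100%, the second highest of the three numbers. Its nearest neighbour is compound 1, with a number 7 percentage points lower from compound 1 to compound 3 (within the scatter); the furthest is compound 2, with a number 7.5 percentage points higher from compound 2 to compound 3 (within the scatter). Both of these steps alter only the ring on the aromatic nitrogen, and neither leaves the scatter.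

Compound 4, `COc1cccc(-n2nc(-c3ccc(C(F)(F)F)cc3O)nc2-c2ccccc2O)c1`, differs from compound 3 in one place: methoxy in place of chloro on an aromatic carbon. The measured steps that bear on this are the exchanges of the ring on the aromatic nitrogen: a number 7 percentage points lower from compound 1 to compound 3 (within the scatter) and a number 7.5 percentage points higher from compound 2 to compound 3 (within the scatter), both within the scatter, and a number 14.5 percentage points lower from compound 1 to compound 2 (beyond the scatter), which is beyond it but modest. Within the data shown here, no measured step introduces methoxy, so the direction of any effect is unknown; the series so far suggests only small movement in this assay from changes at this ring.

Compound 4 is therefore expected to stay close to compound 3, with an estimated step of no change at the digits printed from compound 3 to compound 4 (within the scatter). The estimate for compound 4 in this assay is 100%, in a range from 88% to 110%.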

Compound 4, a percentage reported as activity, at one concentration (the size of the read-out at that concentration, not a potency): 106%
Estimate against measurement, compound 4: 6 percentage points below; measured number inside the range.
By their numbers in this assay, from the lowest: compounds 2, 3, 4 and 1 (each within the scatter of the next, the first and the last beyond it).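

In this assay, among these compounds, the first change at this aromatic carbon, methoxy for chloro, gives a number 6 percentage points higher from compound 3 to compound 4 (within the scatter), so adding a hydrogen-bond acceptor and one more heavy atom here leaves the read-out unresolved from that of the chloro compound. The 3-methoxyphenyl ring also gives a number 1 percentage points lower from compound 1 to compound 4 (within the scatter), while a number 13.5 percentage points higher from compound 2 to compound 4 (beyond the scatter) is a second modest step beyond the scatter involving the 4-(trifluoromethoxy)phenyl ring; compound 3 goes against any separation of that ring from the others, since its step to compound 2 stays within the scatter. No measured evidence bears on the reason for these small differences.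

The compounds shown leave open whether an amine or a carboxylic acid at this carbon would give a step beyond the scatter. They also leave open how far the read-out depends on the shared core, which stays the same throughout.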